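The source may hold more compounds than are shown below. What is called first, only, known or untested is meant among the compounds shown, and "the series" means these compounds.

Working notes on the series. Compound 1, `O=S(=O)(c1cccc(F)c1)c1cn(C2CCCNC2)c2ccccc12`, is tested in an assay on HeLa cells for displacement of a labelled ligand from 5-hydroxytryptamine receptor 6 (Homo sapiens), with a stated time of 2 h (a lower number here means a stronger inhibitor, a higher number a weaker inhibitor), where compound 1 gives 6 nM. Going by the values given here, the second measured member, compound 2, `COc1ccc2c(c1)c(S(=O)(=O)c1cccc(F)c1)cn2C1CCCN(C)C1`, differs from compound 1 in more than one place, so no single step links the two; in this assay compound 2 gives 68 nM, and compound 1 therefore stands lowest of the two numbers so far, with compound 2 the nearest at a gap beyond the scatter.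

The next compound to be measured is compound 3, `O=S(=O)(c1cccc(F)c1)c1cn(C2CCCNC2)c2ccc(F)cc12`. Relative to compound 1 the change is fluoro in place of hydrogen on an aromatic carbon. Among the compounds with values here, no measured pair in this set shows what such a substitution on the shared core does in this assay, and the comparison with compound 2 cannot be read as a step, since it carries two changes at once. The fluoro enters at a position remote from the cyclic amine and the sulfonyl group, and the substituent is small. The expectation is that this assay reports a step from compound 1 to compound 3 of no change at the digits printed from compound 1 to compound 3 (within the scatter), no larger than the usual scatter, in either direction. For compound 3 the estimated value is 6 nM, within a range of 2 nM to 18 nM.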

Compound 3, inhibition constant: 4 nM
Compound 3: middle estimate off by 1.5-fold (0.18 log units), on the high side; measured number inside the range.
By their numbers in this assay, from the lowest: compounds 3 and 1 (each within the scatter of the next); then compound 2.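

The shared core now has its first single-place step: in this assay fluoro in place of hydrogen on an aromatic carbon gives a 1.5-fold lower number from compound 1 to compound 3 (0.18 log units; within the scatter) and so shows what this change does at a carbon of the six-membered aromatic ring of carbon only, meta to a fused ring and para to a fused ring. At this position, the fluoro leaves compound 3 and compound 1 level within the scatter, so the substitution is tolerated in this assay, though a single pair cannot show how far that tolerance extends. Nothing available here gives a measured reason for this result, and the step itself describes only the outcome of the substitution.

This one pair leaves open whether the same position would tolerate a group other than fluoro, such as chloro, an amine or a carboxylic acid, and whether the result with fluoro would carry over to the other carbons of that ring. It also leaves open whether the result would hold on a core with other changes elsewhere, including at the cyclic amine or on the sulfonyl-bearing ring.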